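Changing the amide aryl group from compound 3 to compound 4

A few compounds are considered here, and "the series" means these few. Any claim that something is new, unique, unknown or untested is made for them only; others in the source may bear on it.

Measured compounds and their values in a functional assay on MDA-MB-231 cells (Homo sapiens) for antiproliferative activity, read by CCK-8 assay, with a stated time of 72 h; a higher number here means a weaker inhibitor, a lower number a stronger inhibitor:
compound 1 `COc1ccccc1C(=O)Nc1cccc(-c2oc3cc(-c4ccc(F)cc4)ccc3c(=O)c2O)c1` gives 5110 nM
compound 2 `O=C(Nc1cccc(-c2oc3cc(-c4ccc(F)cc4)ccc3c(=O)c2O)c1)c1cccc(F)c1` gives 2510 nM
compound 3 `COc1cc(OC)cc(C(=O)Nc2cccc(-c3oc4cc(-c5ccc(F)cc5)ccc4c(=O)c3O)c2)c1` gives 4040 nM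

All three share one core and differ only in the aryl group attached to the amide carbonyl. Going by the values given here, compound 3 sits close to both neighbours: the step of a 1.3-fold lower number from compound 1 to compound 3 (0.10 log units; within the scatter) and the step of a 1.6-fold higher number from compound 2 to compound 3 (0.21 log units; within the scatter) both fall inside the usual scatter, so the three numbers are hard to tell apart, and only the step of a 2.0-fold lower number from compound 1 to compound 2 (0.31 log units; beyond the scatter) reaches beyond it.

Compound 4 `O=C(Nc1cccc(-c2oc3cc(-c4ccc(F)cc4)ccc3c(=O)c2O)c1)c1ccc([N+](=O)[O-])cc1` is not yet measured. It differs from compound 3 by 4-nitrophenyl in place of 3,5-dimethoxyphenyl on a carbonyl carbon. Among the compounds with values here, the steps that bear on this change are those that alter the same aryl group: the modest step of a 2.0-fold lower number from compound 1 to compound 2 (0.31 log units; beyond the scatter) and the two smaller steps from compound 1 and compound 2 to compound 3. Together they show that this aryl group moves the number only a little, so the expected step of a 1.3-fold lower number from compound 3 to compound 4 (0.10 log units; within the scatter) is small, within or near the scatter, and with no clear direction. Compound 4 is therefore expected to give about 3200 nM, in a range from 1300 nM to 8000 nM.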

Compound 4, half-maximal inhibitory concentration: 14700 nM
Estimate against measurement, compound 4: 4.6-fold (0.66 log units) below, outside the stated range (above it).
By their numbers in this assay, from the lowest: compounds 2, 3 and 1 (each within the scatter of the next, the first and the last beyond it); then compound 4.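

In this assay, the aryl group on the amide carbonyl matters more than the first three compounds suggested, and 4-nitrophenyl gives the weakest inhibitor of the four. All three comparisons point the same way, with a 3.6-fold higher number from compound 3 to compound 4 (0.56 log units; beyond the scatter) and a 5.9-fold higher number from compound 2 to compound 4 (0.77 log units; beyond the scatter) and also a 2.9-fold higher number from compound 1 to compound 4 (0.46 log units; beyond the scatter) in this small set. The position therefore does not treat every aryl group alike, even though swapping among 2-methoxyphenyl, 3-fluorophenyl and 3,5-dimethoxyphenyl moved the number only modestly.

From the compounds shown here alone, it stays open whether this step belongs to the nitro group itself or to where it sits on the aryl ring, and what an amine or a carboxylic acid in its place would give. Nothing measured here gives a reason for the weaker result.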